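Swapping the fluorophenyl group on the chain of compound 3

The source may hold more compounds than are shown below. What is called first, only, known or untested is meant among the compounds shown, and "the series" means these compounds.

In a functional assay on Caco-2 cells (Homo sapiens) for inhibition, read by MTT assay, with a stated time of 48 h (on this read-out lower numbers stand for stronger inhibition of growth and higher numbers for weaker inhibition of growth), compound 1 `CN1CC[C@H](c2c(O)cc(O)c3c(=O)cc(/C=C/c4ccc(Cl)cc4)oc23)[C@H](O)C1` gives 5600 nM, compound 2 `CN1CC[C@H](c2c(O)cc(O)c3c(=O)cc(/C=C/c4cccc(Cl)c4)oc23)[C@H](O)C1` gives 9000 nM and compound 3 `CN1CC[C@H](c2c(O)cc(O)c3c(=O)cc(/C=C/c4c(F)c(F)c(F)c(F)c4F)oc23)[C@H](O)C1` gives 8000 nM. Compound 3 therefore stands within the scatter of both other compounds, as shown by a 1.4-fold higher number from compound 1 to compound 3 (0.15 log units; within the scatter) and by a 1.1-fold lower number from compound 2 to compound 3 (0.05 log units; within the scatter).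

The next compound is compound 4 `CN1CC[C@H](c2c(O)cc(O)c3c(=O)cc(/C=C/c4ccccc4F)oc23)[C@H](O)C1`, which carries 2-fluorophenyl in place of 2,3,4,5,6-pentafluorophenyl on a double-bonded chain carbon bound to a double-bonded chain carbon.

All three measured steps exchange the group at this same place, so all three bear on the change. Besides the two steps to compound 3, there is a 1.6-fold higher number from compound 1 to compound 2 (0.21 log units; within the scatter). None of the three exceeds the scatter. Going by the values given here, this holds for only three compounds, and none of them carries 2-fluorophenyl, so the data cannot rule out a larger effect from this particular group.

On this evidence, no step beyond the scatter is expected in this assay, and no direction can be assigned with confidence. The expected step is a 1.1-fold lower number from compound 3 to compound 4 (0.06 log units; within the scatter). Compound 4 is estimated at 7000 nM, with an expected range from 3200 nM to 15000 nM.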

Compound 4, concentration for 50% growth inhibition: 7000 nM
The estimate for compound 4 equals the measured number at the digits printed; measured number inside the range.
By their numbers in this assay, from the lowest: compounds 1, 4, 3 and 2 (each within the scatter of the next).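

With 2-fluorophenyl, the series now has a ring carrying a single fluorine on a double-bonded chain carbon bound to a double-bonded chain carbon, and in this assay the new steps are a 1.1-fold lower number from compound 3 to compound 4 (0.06 log units; within the scatter), a 1.3-fold lower number from compound 2 to compound 4 (0.11 log units; within the scatter) and a 1.3-fold higher number from compound 1 to compound 4 (0.10 log units; within the scatter). Even the exchange of 2,3,4,5,6-pentafluorophenyl, with 11 heavy atoms, for 2-fluorophenyl, with 7, leaves the number within the scatter, and so do the exchanges of 2-fluorophenyl for either chlorophenyl group, so all four aryl groups shown at this place are indistinguishable in this read-out. No measurement is available that would explain this flat result.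

Still open, on these data alone, is whether a phenyl ring bearing an amine or a carboxylic acid, or a longer alkyl chain in place of the ring, would give a step beyond the scatter at this place. All four compounds share the core of compound 1, so the result does not show how changes elsewhere on that core would read out, or whether the same flat picture would hold in another assay.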